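Valine-bearing quinone analogue of a terpenoid core

This account rests on a few compounds, and the source may have more. Where it says the series, first, only, none or still open, it means among the compounds named here.

Compound 1 `C=C1[C@H](C)CCC[C@]1(C)CC/C(C)=C/CC1=C(O)C(=O)C=C(OC)C1=O`, compound 2 `COC1=CC(=O)C(O)=C(C/C=C(\C)CC[C@@]2(C)CCC=C(C)[C@H]2C)C1=O` and compound 3 `C=C1[C@H](C)CCC[C@]1(C)CC/C(C)=C/CC1=C(O)C(=O)C=C(N[C@H](C(=O)O)C(C)C)C1=O` were tested in an ADME assay on L1210 cells (Mus musculus) for cytotoxicity, with a stated time of 48 h; on this read-out lower numbers stand for stronger inhibition and higher numbers for weaker inhibition. Compound 1 gives 2.4 ug/mL, compound 2 gives 2 ug/mL, and compound 3 gives 4.4 ug/mL. Compound 2 and compound 1 lie within the scatter of each other, while compound 3 lies beyond the scatter above compound 2. The unmeasured compound 4 `CC1=CCC[C@](C)(CC/C(C)=C/CC2=C(O)C(=O)C=C(N[C@@H](C(=O)O)C(C)C)C2=O)[C@@H]1C` differs from compound 2 by (1-carboxy-2-methylpropyl)amino in place of methoxy on a double-bonded ring carbon. The same change has been seen once already, on the core of compound 1, where the step of a 1.8-fold higher number from compound 1 to compound 3 (0.26 log units; within the scatter) was recorded. Among the measured compounds shown here, that single step is the only guide here, and it stayed within the scatter, so a shift of similar size and in the same direction is expected, though it may well fall within the scatter. Compound 4 is therefore estimated at 3.6 ug/mL, with a range from 1.8 ug/mL to 7 ug/mL, which amounts to an expected step of a 1.8-fold higher number from compound 2 to compound 4 (0.26 log units; within the scatter).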

Compound 4, half-maximal inhibitory concentration: 3 ug/mL
Estimate against measurement, compound 4: 1.2-fold (0.08 log units) above; low and high end bracket the measured number.
By their numbers in this assay, from the lowest: compounds 2, 1, 4 and 3 (each within the scatter of the next, the first and the last beyond it).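

In this assay, the change from methoxy to (1-carboxy-2-methylpropyl)amino on a double-bonded ring carbon now has a second reading, on the core of compound 2 (a 1.5-fold higher number from compound 2 to compound 4 (0.18 log units; within the scatter)). Set beside the earlier reading on the core of compound 1 (a 1.8-fold higher number from compound 1 to compound 3 (0.26 log units; within the scatter)), it shows that the step stays within the scatter on both cores, so the larger group has no effect on this read-out that can be told from the scatter in either pair. No measurement shown accounts for this result.

Methoxy and (1-carboxy-2-methylpropyl)amino are the only groups shown at this position, so it remains open how a simple amine, a methyl ester of the same amino group or a longer chain ending in a carboxylic acid would read there. Also open, on these data alone, is whether the carboxy part or the branched chain of the entering group matters on its own.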